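This account rests on a few compounds, and the source may have more. Where it says the series, first, only, none or still open, it means among the compounds named here.

Measured so far in an ADME assay on the whole organism for pharmacokinetics, with Rattus norvegicus as the target; a lower number here means that a smaller share of the oral dose reaches the circulation, a higher number that a larger share of the oral dose reaches the circulation:

- compound 1 `O=S(=O)(c1ccc(O)c2ncccc12)C1CCCC1`: 24%
- compound 2 `O=S(=O)(c1ccc(F)cc1)c1cc(Cl)c(O)c2ncccc12`: 23%
- compound 3 `O=S(=O)(c1cc(F)c(O)c2ncccc12)C1CCCC1`: 32%

Compound 3, at 32%, lies within the scatter of both compound 1 and compound 2, so the three values cannot be ranked. The next compound to be tested is compound 4 `O=S(=O)(c1cc(Cl)c(O)c2ncccc12)C1CCCC1`, which departs from compound 3 by a single exchange: chloro in place of fluoro on an aromatic carbon. This is chloro in place of fluoro on an aromatic carbon, ortho to a hydroxy group.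

For the measured compounds named here, no measured step covers this exchange directly. The closest evidence is the step at the same carbon, fluoro in place of hydrogen, a number 8 percentage points higher from compound 1 to compound 3 (within the scatter), and it stayed within the scatter. Going by the values given here, compound 2 also carries chloro at that carbon and gives 23%, but it differs from compound 4 elsewhere in the structure as well, so it offers no clean step. It does show a chloro compound with a value within the scatter of compound 3.

No change beyond the scatter is therefore expected, and the expected difference is a number 5 percentage points lower from compound 3 to compound 4 (within the scatter). For compound 4 the estimated value is 27%, with an expected range from 15% to 40%.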

Compound 4, oral bioavailability: 37%
Beside the measured number, compound 4's estimate is 10 percentage points below it; the measured number falls inside the stated range.
By their numbers in this assay, from the lowest: compounds 2, 1, 3 and 4 (each within the scatter of the next, the first and the last beyond it).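

In this assay, at this aromatic carbon ortho to a hydroxy group, the exchange of fluoro for chloro gives a step within the scatter (a number 5 percentage points higher from compound 3 to compound 4 (within the scatter)), so the two halogens cannot be told apart here, yet the step from hydrogen to chloro at the same carbon (a number 13 percentage points higher from compound 1 to compound 4 (beyond the scatter)) goes beyond the scatter, as the step to fluoro (a number 8 percentage points higher from compound 1 to compound 3 (within the scatter)) did not. For the compounds shown here, with chloro held in place, the group on the sulfonyl sulfur also counts, since cyclopentyl in place of 4-fluorophenyl gives a modest step beyond the scatter (a number 14 percentage points higher from compound 2 to compound 4 (beyond the scatter)), the first such single-place reading at that sulfur. No measurement at hand accounts for either of these steps.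

The compounds shown leave open whether a group other than a halogen at this carbon, such as methyl, methoxy or nitrile, would keep the share reaching the circulation where compound 4 stands. They also leave open whether a sulfonyl substituent other than cyclopentyl or 4-fluorophenyl, such as a longer chain or a ring bearing an amine, would go further than cyclopentyl does.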